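This account rests on a few compounds, and the source may have more. Where it says the series, first, only, none or still open, it means among the compounds named here.

Measured compounds in a functional assay on MCF7 cells (Homo sapiens) for cytotoxicity, read by MTT assay, with a stated time of 48 h; on this read-out lower numbers stand for stronger inhibition and higher numbers for weaker inhibition:

compound 1, `COc1ccc(N/C(CCNC2=CC(=O)c3ccccc3C2=O)=N\S(=O)(=O)c2ccc(C)cc2)cc1`: 6030 nM
compound 2, `Cc1ccc(S(=O)(=O)/N=C(/CCNC2=CC(=O)c3ccccc3C2=O)Nc2ccc(F)cc2)cc1`: 4260 nM
compound 3, `Cc1ccc(S(=O)(=O)/N=C(/CCNC2=CC(=O)c3ccccc3C2=O)Nc2ccc(F)c(F)c2)cc1`: 9420 nM

Compound 2 carries the lowest number of the three. The two steps that touch it run in opposite directions: a 1.4-fold lower number from compound 1 to compound 2 (0.15 log units; within the scatter), and a 2.2-fold higher number from compound 2 to compound 3 (0.34 log units; beyond the scatter). Only the second of these lies beyond the scatter, and it shows that a fluoro added to the aryl on the amine nitrogen carried the number up by a modest amount.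

The next compound, compound 4, is `Cc1ccc(S(=O)(=O)/N=C(/CCNC2=CC(=O)c3ccccc3C2=O)Nc2ccc(Cl)cc2Cl)cc1`. Relative to compound 2 the change is 2,4-dichlorophenyl in place of 4-fluorophenyl on an amine nitrogen. Within the data shown here, no measured step covers chlorine at this position, nor two substituents at once on this aryl; the step from compound 1 to compound 3, a 1.6-fold higher number from compound 1 to compound 3 (0.19 log units; within the scatter), is the only other exchange of the whole aryl and is within the scatter. Among the measured compounds shown here, the one step beyond the scatter, a 2.2-fold higher number from compound 2 to compound 3 (0.34 log units; beyond the scatter), suggests that adding substituents here moves the number upward, so a small-to-modest rise in this assay is expected, with wide uncertainty. Compound 4 is therefore estimated at about 6500 nM, between 2500 nM and 17000 nM, which would mean a 1.5-fold higher number from compound 2 to compound 4 (0.18 log units; within the scatter).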

Compound 4, half-maximal inhibitory concentration: 17000 nM
Compound 4: middle estimate off by 2.6-fold (0.42 log units), on the low side, and the stated range covers the measured number.
By their numbers in this assay, from the lowest: compounds 2, 1, 3 and 4 (each within the scatter of the next, the first and the last beyond it).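

In this assay, the exchange to 2,4-dichlorophenyl on the amine nitrogen lies beyond the scatter against both aryls bearing a single substituent (a 4.0-fold higher number from compound 2 to compound 4 (0.60 log units; beyond the scatter); a 2.8-fold higher number from compound 1 to compound 4 (0.45 log units; beyond the scatter)), whereas 3,4-difluorophenyl stood beyond the scatter only against 4-fluorophenyl. Between the two aryls bearing two halogens the exchange stays within the scatter (a 1.8-fold higher number from compound 3 to compound 4 (0.26 log units; within the scatter)), so this position does not separate chlorine from fluorine in these two compounds, which also differ in where the halogens sit. No evidence on the cause of these steps is at hand.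

From the compounds shown here alone, whether a single chlorine on this aryl would already carry the number upward remains open. Also open, going by these compounds, is how an amine or a carboxylic acid on this aryl would compare with the halogens.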